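A few compounds are considered here, and "the series" means these few. Any claim that something is new, unique, unknown or untested is made for them only; others in the source may bear on it.

The measured compounds:
- compound 1, `NCc1csc(NC(=O)c2cnn[nH]2)n1`, with -0.3 in a physicochemical assay for lipophilicity, read by HPLC, at pH 7.4; on this read-out higher numbers stand for higher lipophilicity and lower numbers for lower lipophilicity
- compound 2, `NCc1csc(NC(=O)c2cnnn2Cc2ccccc2)n1`, with 1.6
- compound 3, `CC(C)(C)c1cc(C(=O)Nc2ccncc2)n(Cc2ccccc2)n1`, with 4

Compound 3 stands highest of the three numbers in this assay: compound 2 lies nearest to it and compound 1 furthest, both gaps beyond the scatter. Compound 4, `CNCc1csc(NC(=O)c2cc(C(C)(C)C)nn2Cc2ccccc2)n1`, differs from compound 3 in one place: 4-((methylamino)methyl)-1,3-thiazol-2-yl in place of pyridin-4-yl on an amide-type nitrogen. Among the compounds with values here, the only measured step, a number 1.90 log units higher from compound 1 to compound 2 (beyond the scatter), concerns a benzyl on an aromatic nitrogen and leaves the amide-type nitrogen untouched, so no measured step bears directly on the change from compound 3 to compound 4. Within the data shown here, what the numbers do show is that compound 2, whose amide-type nitrogen carries a group closely resembling the one that enters in compound 4, sits well below compound 3, although the two differ in more than one place. On that basis a downward step is expected, a number 1.70 log units lower from compound 3 to compound 4 (beyond the scatter), beyond the scatter. Compound 4 is therefore estimated at 2.3, with a range from 1.3 to 3.3.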

Compound 4, distribution coefficient: 3.8
Estimate against measurement, compound 4: 1.50 log units below; measured number outside the range, above it.
By their numbers in this assay, from the lowest: compound 1; then compound 2; then compounds 4 and 3 (each within the scatter of the next).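

In this assay, within the data shown here, replacing pyridin-4-yl with 4-((methylamino)methyl)-1,3-thiazol-2-yl on the amide-type nitrogen gives a number 0.20 log units lower from compound 3 to compound 4 (within the scatter) and is the first step read at this place, the earlier step having concerned a benzyl on an aromatic nitrogen. At this place, on this read-out, the two groups cannot be told apart, although the entering group has 1 hydrogen-bond donor and 3 hydrogen-bond acceptors where the leaving group has 0 and 1, and it has 8 heavy atoms where the leaving group has 6. Nothing available accounts for this result.

The compounds shown do not separate the contribution of the five-membered aromatic ring from that of its (methylamino)methyl group, so it remains open how the read-out would respond to a plain thiazol-2-yl or to a carboxylic acid in place of that amine. As far as these compounds go, it is also open whether the same exchange would give a similar result on a different core, such as that of compound 2, or alongside a hydrogen in place of the tert-butyl group of compound 3.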